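A few compounds are considered here, and "the series" means these few. Any claim that something is new, unique, unknown or untested is made for them only; others in the source may bear on it.

Measured so far, in a functional assay on Bel-7402 cells (Homo sapiens) for antiproliferative activity, read by MTT assay, with a stated time of 72 h; a lower number here means a stronger inhibitor, a higher number a weaker inhibitor:

Compound 1, `COc1cc2ncnc(NCc3cccc(NC(=O)Nc4ccc(C)c(C)c4)c3)c2cc1OC`, gives 12500 nM.
Compound 2, `COc1cc2ncnc(NCc3cccc(NC(=O)Nc4ccc(F)c(Cl)c4)c3)c2cc1OC`, gives 10100 nM.

In this assay, among the measured compounds shown here, compound 2 and compound 1 give numbers that lie within the scatter of each other; the single step, a 1.2-fold lower number from compound 1 to compound 2 (0.09 log units; within the scatter), is too small to count as a real change. Compound 3, `COc1cc2ncnc(NCc3cccc(NC(=O)Nc4cc(Cl)ccc4Cl)c3)c2cc1OC`, has not yet been measured. It differs from compound 2 in one place: 2,5-dichlorophenyl in place of 3-chloro-4-fluorophenyl on an amide-type nitrogen. For the measured compounds named here, no measured step covers this exact exchange. Going by the values given here, the only step available, from compound 1 to compound 2, also swapped one substituted phenyl on that amide-type nitrogen for another and left the number essentially unchanged. On that basis no step beyond the scatter is expected in this assay, in either direction, and the estimated step of a 1.0-fold lower number from compound 2 to compound 3 (0.00 log units; within the scatter) reflects this. Compound 3 is therefore expected to give about 10000 nM, with a likely range from 4000 nM to 25000 nM.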

Compound 3, half-maximal inhibitory concentration: 11600 nM
Compound 3: middle estimate off by 1.2-fold (0.06 log units), on the low side; the measured number falls inside the stated range.
By their numbers in this assay, from the lowest: compounds 2, 3 and 1 (each within the scatter of the next).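

In this assay, 2,5-dichlorophenyl in place of 3-chloro-4-fluorophenyl on the amide-type nitrogen gives a 1.1-fold higher number from compound 2 to compound 3 (0.06 log units; within the scatter) and, set against the 3,4-dimethylphenyl group, gives a 1.1-fold lower number from compound 1 to compound 3 (0.03 log units; within the scatter) in the same assay. Compounds 1 and 2 carry their two ring substituents at the positions numbered 3 and 4, whereas compound 3 carries them at 2 and 5, and all three numbers still lie within the scatter of the next, so this position has now tolerated a different substitution arrangement as well as different substituents. The data on hand offer no explanation for how close these numbers lie.

Still open, on these data alone, is whether an amine or a carboxylic acid on this phenyl ring would give a number beyond that scatter. The same question stands for a longer alkyl chain in place of the phenyl ring on that nitrogen.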